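The compounds below may be only part of what the source reports. "The series", "measured", "known", "first", "only" and "open" are said of these compounds alone.

Series notes, indole-substituted tricyclic esters.

The shared core carries a methyl ester and an indolylmethyl arm. Compound 1 `COC(=O)[C@@]1(C)CCC=C2[C@@H]1CC[C@@H](C)[C@]2(C)Cc1c[nH]c2c(C)cccc12` has a methyl on the six-membered aromatic ring of the indole; compound 2 `COC(=O)[C@@]1(C)CCC=C2[C@@H]1CC[C@@H](C)[C@]2(C)Cc1c(C)[nH]c2ccccc12` has a methyl on the five-membered ring instead; compound 3 `COC(=O)[C@@]1(C)CCC=C2[C@@H]1CC[C@@H](C)[C@]2(C)Cc1c(C)[nH]c2ccc(C(F)(F)F)cc12` adds a trifluoromethyl to compound 2. In a functional assay on T47D cells (Homo sapiens) for inhibition, read by sulforhodamine B assay, with a stated time of 48 h (a lower number here means a stronger inhibitor of growth, a higher number a weaker inhibitor of growth), compound 1 gives 18000 nM, compound 2 gives 17000 nM and compound 3 gives 21000 nM. Compound 2 holds the lowest of the three numbers, but its gaps to compound 1 and compound 3 both lie within the scatter, so no order can be read among them. Going by the values given here, the one single-point step in hand, a 1.2-fold higher number from compound 2 to compound 3 (0.09 log units; within the scatter), is flat.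

Compound 4 `COC(=O)[C@@]1(C)CCC=C2[C@@H]1CC[C@@H](C)[C@]2(C)Cc1c(C)[nH]c2c(C)cccc12` differs from compound 2 by methyl in place of hydrogen on an aromatic carbon. Among the compounds with values here, no step with exactly this change is on hand; the values of compound 1 and compound 2 show that a methyl at either ring position gives much the same number, and the flat step from compound 2 to compound 3 shows the six-membered ring tolerating a substituent without effect. For compound 4 the expected step is therefore no change at the digits printed from compound 2 to compound 4 (within the scatter), none beyond the scatter. Compound 4 is estimated at 17000 nM in this assay, within a range of 9000 nM to 34000 nM.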

Compound 4, concentration for 50% growth inhibition: 19000 nM
Estimate against measurement, compound 4: 1.1-fold (0.05 log units) below, and the stated range covers the measured number.
By their numbers in this assay, from the lowest: compounds 2, 1, 4 and 3 (each within the scatter of the next).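

In this assay, going by these compounds alone, the methyl on the aromatic carbon of the six-membered aromatic ring now has direct single-change readings, where the earlier compounds only allowed the two singly methylated indoles to be set side by side. Adding this methyl gives a 1.1-fold higher number from compound 2 to compound 4 (0.05 log units; within the scatter), and the counterpart change, which adds a methyl to the five-membered ring of compound 1, gives a 1.1-fold higher number from compound 1 to compound 4 (0.02 log units; within the scatter), so carrying both methyls leaves the number flat from either starting point. No measured finding is available that would explain this flatness.

Methyl is the only group shown at this position, so it remains open whether an amine, a carboxylic acid or a longer chain there would move the number beyond the scatter. From the compounds shown here alone, the indole carrying neither methyl also remains open as a reference point, so the contribution of each methyl against hydrogen on the bare indole cannot be read.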